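Swapping the Amide Aryl Group and Vero Cell Cytotoxicity

A few compounds are considered here, and "the series" means these few. Any claim that something is new, unique, unknown or untested is made for them only; others in the source may bear on it.

Three measured compounds share one core and differ only in the group attached to the carbonyl carbon of an amide. Compound 1 `CCOCCOC(=O)Nc1cc2nc(C3CCCCC3)[nH]c2cc1N(C)C` carries a 2-ethoxyethoxy group there; in an ADME assay on Vero cells (Chlorocebus sabaeus) for cytotoxicity, read by resazurin assay, with a stated time of 3 days (on this read-out higher numbers stand for weaker inhibition and lower numbers for stronger inhibition), compound 1 gives > 100 ug/mL, which is a limit of the assay rather than a number. Compound 2 `COc1ccc(C(=O)Nc2cc3nc(C4CCCCC4)[nH]c3cc2N(C)C)cc1` carries a 4-methoxyphenyl group instead, and in this assay compound 2 gives > 100 ug/mL, again a limit. Compound 3 `CCc1ccc(C(=O)Nc2cc3nc(C4CCCCC4)[nH]c3cc2N(C)C)cc1` carries a 4-ethylphenyl group, and compound 3 gives > 100 ug/mL, also a limit. Compound 3 thus stands exactly where every measured compound stands, at the limit of > 100 ug/mL in this assay, at which 3 of the 3 values shown sit. The three steps between them, a step that the two limits leave unreadable from compound 1 to compound 2, a step that the two limits leave unreadable from compound 1 to compound 3 and a step that the two limits leave unreadable from compound 2 to compound 3, cannot be sized, since both ends of each are limits.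

Compound 4 `CN(C)c1cc2[nH]c(C3CCCCC3)nc2cc1NC(=O)c1cccc(Br)c1` is not yet measured. It differs from compound 3 by 3-bromophenyl in place of 4-ethylphenyl on a carbonyl carbon. Going by the values given here, the steps that bear on this change all join compounds sitting at the same limit, so no direction can be read from them. The expected step is therefore a number no higher from compound 3 to compound 4 (the limit leaves the size open), nothing beyond the scatter. Compound 4 is expected to give about 100 ug/mL, between 50 ug/mL and 200 ug/mL, most likely reported once more as a limit.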

Compound 4, half-maximal inhibitory concentration: > 100 ug/mL
Compound 4: no number, only a limit; the forecaster's own chance of this, stated with the estimate: 85%; the middle value lies on the limit itself.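

In this assay compound 4 gives > 100 ug/mL, a limit and not a number. Its steps from compound 1, compound 2 and compound 3 join limit to limit, so none of them can be read. The compounds shown leave open whether changing the group on the carbonyl carbon alters cytotoxicity at all, as every value sits at one ceiling: the limit of > 100 ug/mL in this assay, at which 4 of the 4 values shown sit.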